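Methoxy in Place of Nitro on the Benzyl Arm

The source may report more compounds than this note shows. Statements on the series, on what has been measured and on what is new or still open speak of the compounds shown alone.

Compound 1 `N=C(NCc1ccccc1)[C@@H]1CCC(=O)N1Cc1ccc([N+](=O)[O-])cc1` is the point of departure. Within the data shown here, in a functional assay on SH-SY5Y cells (Homo sapiens) for cytotoxicity, read by MTT assay, with stated times of 8 h, 30 min and 12 h, tested at 5 uM (on this read-out lower numbers stand for a weaker effect and higher numbers for a stronger effect at the one concentration tested), compound 1 gives 25.6%, and it stands alongside the only other measured compound, compound 2 `N=C(NCc1ccc(O)cc1)[C@@H]1CCC(=O)N1Cc1ccc([N+](=O)[O-])cc1`, whose number lies within the usual scatter of it: in this assay compound 2 gives 34.5%, and the step of a number 8.9 percentage points higher from compound 1 to compound 2 (within the scatter) is too small to read as a real change.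

Compound 3 `COc1ccc(CN2C(=O)CC[C@H]2C(=N)NCc2ccccc2)cc1` has not yet been measured. It differs from compound 1 in one place: methoxy in place of nitro on an aromatic carbon. Among the measured compounds shown here, no measured step touches this group. For the measured compounds named here, the single step available, a number 8.9 percentage points higher from compound 1 to compound 2 (within the scatter), concerns a hydroxy on a different ring and was itself within the scatter, so it says nothing about what the exchange of nitro for methoxy should do. There is thus no measured guide for the size or direction of the change, and the neutral expectation is a step no larger than the scatter, with wide uncertainty. Compound 3 is expected to give 26%, within 8% to 46%. The expected step of a number 0.4 percentage points higher from compound 1 to compound 3 (within the scatter) is accordingly one of no change beyond the scatter.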

Compound 3, a percentage reported as activity, at one concentration (the size of the read-out at that concentration, not a potency): 17.9%
The estimate for compound 3 lay 8.1 percentage points above the measured number, within the range that was stated.
By their numbers in this assay, from the lowest: compounds 3, 1 and 2 (each within the scatter of the next, the first and the last beyond it).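

In this assay, among these compounds, the exchange of nitro for methoxy on an aromatic carbon para to a large group gives a number 7.7 percentage points lower from compound 1 to compound 3 (within the scatter), the first measured step at this position. Compound 1 and compound 3 therefore cannot be told apart in this read-out, so nitro at this position is not needed to keep the number within the scatter of compound 1, and methoxy serves equally well here. No measurement available here bears on why this exchange leaves the number within the scatter.

What the compounds shown leave open is whether any group on this aromatic carbon can move the number beyond the scatter, since a single exchange cannot show how tolerant the position is, and an amine, a carboxylic acid or a longer alkoxy chain in the same place would each put that to the test. Also open is what the hydroxy on the other ring, whose step from compound 1 was itself within the scatter, would do when paired with methoxy on this arm, and how any of these compounds would behave at concentrations other than the one tested.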